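Nitro Substitution Repeated on a Second Core

This account rests on a few compounds, and the source may have more. Where it says the series, first, only, none or still open, it means among the compounds named here.

Measured compounds:
compound 1, `O=Cc1c(-c2ccccc2)nc2sc(Cc3ccc(Cl)cc3)nn12`: 22000 nM
compound 2, `O=Cc1c(-c2ccc([N+](=O)[O-])cc2)nc2sc(Cc3ccc(Cl)cc3)nn12`: 13000 nM
compound 3, `N#CSc1c(-c2ccccc2)nc2sc(Cc3ccc(Cl)cc3)nn12`: 14000 nM

All three were tested in an ADME assay on CCRF-CEM cells (Homo sapiens) for cytotoxicity, with a stated time of 72 h; a lower number here means a stronger inhibitor, a higher number a weaker inhibitor. Compound 1 and compound 2 differ by nitro in place of hydrogen on an aromatic carbon, and that change gave a 1.7-fold lower number from compound 1 to compound 2 (0.23 log units; within the scatter). Compound 3 carries a different core: compared with compound 1 its difference is cyanosulfanyl in place of formyl on an aromatic carbon, and the move gave a 1.6-fold lower number from compound 1 to compound 3 (0.20 log units; within the scatter). Compound 2 and compound 3 lie within the scatter of each other.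

Compound 4, `N#CSc1c(-c2ccc([N+](=O)[O-])cc2)nc2sc(Cc3ccc(Cl)cc3)nn12`, has not yet been measured. It stands to compound 3 as compound 2 stands to compound 1: the change is nitro in place of hydrogen on an aromatic carbon, the same change seen once before, with the place described in the same words. Because the earlier step of a 1.7-fold lower number from compound 1 to compound 2 (0.23 log units; within the scatter) was small, the step from compound 3 to compound 4 in this assay is expected to be similarly small, a 1.6-fold lower number from compound 3 to compound 4 (0.22 log units; within the scatter). Resting on that single precedent and on the value 14000 nM of compound 3, compound 4 is estimated at 8500 nM, with a likely range from 4000 nM to 20000 nM.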

Compound 4, half-maximal inhibitory concentration: 20000 nM
The estimate for compound 4 lay 2.4-fold (0.37 log units) below the measured number; low and high end bracket the measured number.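

In this assay, nitro in place of hydrogen on the second core gave a 1.4-fold higher number from compound 3 to compound 4 (0.15 log units; within the scatter), and cyanosulfanyl in place of formyl with the 4-nitrophenyl group present gave a 1.5-fold higher number from compound 2 to compound 4 (0.19 log units; within the scatter). The nitro change shows no difference between the two cores that stands clear of the scatter, but it also does not show that the change has a real effect on either core, as each step is small: the same change on two cores in this assay, a 1.7-fold lower number (0.23 log units; within the scatter) from compound 1 to compound 2 and a 1.4-fold higher number (0.15 log units; within the scatter) from compound 3 to compound 4, 2.4-fold (0.38 log units) apart, within the scatter of two such steps The same reading holds for cyanosulfanyl in place of formyl, so these four compounds neither confirm nor rule out that either change carries from one core to the other: the same change on two cores in this assay, a 1.6-fold lower number (0.20 log units; within the scatter) from compound 1 to compound 3 and a 1.5-fold higher number (0.19 log units; within the scatter) from compound 2 to compound 4, 2.4-fold (0.38 log units) apart, within the scatter of two such steps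

As far as these compounds go, it remains open whether an amine or a carboxylic acid in the place held by nitro would move the number beyond the scatter on either core. From the compounds shown here alone, it is equally open whether a step of that larger size, if one exists, would carry across the two cores.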